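A few compounds are considered here, and "the series" means these few. Any claim that something is new, unique, unknown or untested is made for them only; others in the source may bear on it.

Series on the shared core of compound 1 `Cc1cc(/C=C2\SC(=S)N(c3ccccc3)C2=O)c(C)n1-c1ccc(O)c(C(=O)O)c1`, varied on the amide-type nitrogen in the ring, tested in an ADME assay on MT2 cells (Homo sapiens) for cytotoxicity, read by XTT assay, with a stated time of 4 days; on this read-out lower numbers stand for higher toxicity in this test and higher numbers for lower toxicity in this test. Compound 1 carries phenyl on that nitrogen. In this assay compound 1 gives only a limit of the assay, > 100000 nM. Compound 2 `COC(=O)c1ccc(CN2C(=O)/C(=C/c3cc(C)n(-c4ccc(O)c(C(=O)O)c4)c3C)SC2=S)cc1` carries 4-(methoxycarbonyl)benzyl there, and in this assay compound 2 gives 36900 nM. Compound 3 `Cc1cc(/C=C2\SC(=S)N(Cc3ccc(C(C)(C)C)cc3)C2=O)c(C)n1-c1ccc(O)c(C(=O)O)c1` carries 4-(tert-butyl)benzyl, and in this assay compound 3 gives 55200 nM. Among the numbers shown compound 3 stands alongside compound 2, the step of a 1.5-fold higher number from compound 2 to compound 3 (0.17 log units; within the scatter) lying within the scatter, while compound 1 is known only as a limit (the limit of > 100000 nM in this assay, at which 1 of the 3 values shown sits). From phenyl to the two benzyl groups the steps were an at least 2.7-fold lower number from compound 1 to compound 2 (0.43 log units; beyond the scatter) and an at least 1.8-fold lower number from compound 1 to compound 3 (0.25 log units; that floor lies within the scatter), the first beyond the scatter, the second not.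

Compound 4 `Cc1cc(/C=C2\SC(=S)N(Cc3cccc(Br)c3)C2=O)c(C)n1-c1ccc(O)c(C(=O)O)c1` differs from compound 3 by 3-bromophenyl in place of 4-(tert-butyl)phenyl on a saturated chain carbon bound to an amide-type nitrogen in a ring. The step that bears most directly is the substituent swap on the benzyl ring, a 1.5-fold higher number from compound 2 to compound 3 (0.17 log units; within the scatter), which stayed within the scatter; the phenyl-to-benzyl steps do not apply, as compound 3 and compound 4 both keep a benzyl. Going by the values given here, a 3-bromobenzyl has no measured precedent in the set. The expectation is therefore no step beyond the scatter, a 1.2-fold lower number from compound 3 to compound 4 (0.09 log units; within the scatter). Compound 4 is estimated at 45000 nM in this assay, with a range of 20000 nM to 100000 nM.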

Compound 4, half-maximal cytotoxic concentration: 48200 nM
Beside the measured number, compound 4's estimate is 1.1-fold (0.03 log units) below it; measured number inside the range.
By their numbers in this assay, from the lowest: compounds 2, 4 and 3 (each within the scatter of the next). At a limit, above all of these: compound 1.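

In this assay, a third benzyl group with a different substituent gives no separation from the first two: a 1.1-fold lower number from compound 3 to compound 4 (0.06 log units; within the scatter) and a 1.3-fold higher number from compound 2 to compound 4 (0.12 log units; within the scatter) both lie within the scatter, even though 3-bromophenyl has fewer heavy atoms than 4-(tert-butyl)phenyl. Against phenyl, an at least 2.0-fold lower number from compound 1 to compound 4 (0.31 log units; beyond the scatter) is a floor beyond the scatter, so compound 4 joins compound 2 in clearing the scatter, while the floor printed for compound 3 does not clear it and stands as the exception among the three benzyl compounds. Compound 1 is known only as a limit of the assay, so these phenyl-to-benzyl steps give only floors and not full sizes: the limit of > 100000 nM in this assay, at which 1 of the 4 values shown sits.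

Still open, on these data alone, is whether 4-bromobenzyl would read like 3-bromobenzyl, which would separate the identity of the substituent from its place on the ring. Also open, as far as these compounds go, is whether an amine or a carboxylic acid on the benzyl ring, or a longer chain in place of the saturated chain carbon on the amide-type nitrogen, would move the number in this assay beyond the scatter.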